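The source may report more compounds than this note shows. Statements on the series, on what has been measured and on what is new or still open speak of the compounds shown alone.

Measured in a functional assay on U-373MG ATCC cells for cytotoxicity against U373 MG (Homo sapiens), read by colorimetric assay and MTT assay; a higher number here means a weaker inhibitor, a lower number a stronger inhibitor:
- compound 1 `CCN(CC)C(=O)Cn1c(=O)c(-c2ccc(OC)cc2)cc2c(OC)cc(OC)cc21`: 10000 nM
- compound 2 `COc1ccc(-c2cc3c(OC)cc(OC)cc3n(CCC(=O)OCc3ccccc3)c2=O)cc1`: 10000 nM

Level with compound 1, compound 2 stands at 10000 nM.

Compound 3 `CCN(CC)C(=O)CCn1c(=O)c(-c2ccc(OC)cc2)cc2c(OC)cc(OC)cc21` has not been measured. It differs from compound 2 in one place, with diethylamino in place of benzyloxy on a carbonyl carbon. The same difference also reads benzyloxycarbonyl to diethylcarbamoyl.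

Going by the values given here, only one measured step bears on this change: no change at the digits printed from compound 1 to compound 2 (within the scatter). That step exchanged diethylcarbamoyl and (benzyloxycarbonyl)methyl on a saturated chain carbon bound to an aromatic nitrogen, and it showed no size beyond the scatter. Among the compounds with values here, one step is thin evidence, and no measured compound in this set yet stands clearly apart from the others in this assay. No direction can be drawn from it, so no shift beyond the scatter is expected. The expected step is no change at the digits printed from compound 2 to compound 3 (within the scatter).

For compound 3 the estimated value is 10000 nM, with an expected range of 5000 nM to 20000 nM.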

Compound 3, half-maximal inhibitory concentration: 10000 nM
The estimate for compound 3 equals the measured number at the digits printed; the measured number falls inside the stated range.
By their numbers in this assay, from the lowest: compounds 1, 2 and 3 (each within the scatter of the next).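

In this assay, diethylamino in place of benzyloxy on the carbonyl carbon gives no change at the digits printed from compound 2 to compound 3 (within the scatter), so the benzyloxycarbonyl to diethylcarbamoyl change, with its loss of the aromatic ring, is now seen on its own at a fixed chain. The change from diethylcarbamoyl to (diethylcarbamoyl)methyl on the saturated chain carbon bound to an aromatic nitrogen gives no change at the digits printed from compound 1 to compound 3 (within the scatter), which separates the chain difference from the end-group difference that were combined in the earlier step between compound 1 and compound 2. Neither single change moves the value, but no measurement at hand explains this result.

Going by these compounds, with compound 3 at 10000 nM, it remains open whether a free carboxylic acid, a basic amine or a longer chain in place of the diethylcarbamoyl end would give a value apart from this one. Also open, on these data alone, is whether any change elsewhere on the shared core, such as a hydroxyl in place of a methoxy group, would move the read-out in this assay.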